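A few compounds are considered here, and "the series" means these few. Any claim that something is new, unique, unknown or untested is made for them only; others in the source may bear on it.

Working notes on the series. Three compounds carry a number in a functional assay on the whole organism (stomach) for inhibition, with Rattus norvegicus as the target, at a dose of 100 mg/kg by the intraduodenal route; a lower number here means less inhibition, a higher number more inhibition at the dose given (going by the name of the read-out): compound 1 `CC/N=C(\S)CCn1nc(-c2ccccc2)ccc1=O` gives 50.3%, compound 2 `Cc1ccc(=O)n(CC(=N)S)n1` gives 31.5%, and compound 3 `Cc1cc(-c2ccccc2)nn(CCC(=N)S)c1=O` gives 60.2%. Compound 1 stands second highest of the three; its gap to compound 3 lies within the scatter, while compound 2 sits beyond the scatter below it. Compound 4 `N=C(S)CCCCCn1nc(-c2ccccc2)ccc1=O` is not yet measured in this assay. It differs from compound 1 in one place: a group of 6 heavy atoms (4 carbon, 1 nitrogen, 1 sulfur; no ring) in place of a group of 5 heavy atoms (3 carbon, 1 nitrogen, 1 sulfur; no ring), on a saturated chain carbon, two bonds along the chain from an aromatic nitrogen. For the measured compounds named here, no step between measured compounds pairs with this change. With compound 3, which also carries an unsubstituted group on the chain, giving 60.2% close to compound 1, no step beyond the scatter is expected for compound 4, so a number 1.7 percentage points higher from compound 1 to compound 4 (within the scatter) is the estimated step. Compound 4 is therefore expected at 52%, in a range of 30% to 72%.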

Compound 4, a percentage reported as inhibition, in the whole organism at one dose (the size of the read-out at that dose, not a potency): 91.4%
Beside the measured number, compound 4's estimate is 39.4 percentage points below it, outside the stated range (above it).
By their numbers in this assay, from the lowest: compound 2; then compounds 1 and 3 (each within the scatter of the next); then compound 4.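

In this assay, replacing the group of 5 heavy atoms (3 carbon, 1 nitrogen, 1 sulfur; no ring) with the group of 6 heavy atoms (4 carbon, 1 nitrogen, 1 sulfur; no ring) gives a number 41.1 percentage points higher from compound 1 to compound 4 (beyond the scatter). For the compounds shown here, the read-out at this dose is therefore sensitive to a single change on a saturated chain carbon, two bonds along the chain from an aromatic nitrogen, which no earlier pair could show. Nothing available accounts for the size of this step.

From the compounds shown here alone, whether a longer chain, an amine or a carboxylic acid at this place would hold the read-out stays open. A single dose also leaves potency unresolved.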